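A few compounds are considered here, and "the series" means these few. Any claim that something is new, unique, unknown or untested is made for them only; others in the source may bear on it.

Measured compounds in an ADME assay on Raji cells (Homo sapiens) for cytotoxicity, read by CellTiter-Glo and resazurin assay, with a stated time of 72 h; a higher number here means that more compound is needed for the effect, a lower number that less compound is needed:
Compound 1 `CC(C)N(Cc1cccc(OCCCCCC(=O)O)c1)C(=O)c1ccccc1` gives > 26000 nM, which is a limit of the assay and not a number.
Compound 2 `COc1cc(OC)cc(-c2ccc(C(=O)N(Cc3cccc(OCCCCCC(=O)O)c3)C(C)C)cc2)c1` gives > 26000 nM, again only a limit.
Compound 3 `CCOC(=O)CCCCCOc1cccc(CN(C(=O)c2ccccc2)C(C)C)c1` gives > 26000 nM, also only a limit.

In this assay compound 3 therefore stands only at a limit, and the two other values shown are limits as well. Two measured steps lead away from compound 1: a step that the two limits leave unreadable from compound 1 to compound 2 and a step that the two limits leave unreadable from compound 1 to compound 3. Neither tells how large a change either structural edit produced, because of the limit of > 26000 nM in this assay, at which 3 of the 3 values shown sit.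

Compound 4 `CCOC(=O)CCCCCOc1cccc(CN(C(=O)c2ccc(-c3cccc(-c4ccccc4)c3)cc2)C(C)C)c1` differs from compound 3 in one place: 3-phenylphenyl in place of hydrogen on an aromatic carbon. Among the measured compounds shown here, the one measured step that adds an aromatic group on the same kind of position, from compound 1 to compound 2, gave no readable size, so there is no measured guide to the direction or size of the change in this assay. The working expectation is no step beyond the scatter, and that compound 4 stays at the limit, which is what a step that the limit leaves unreadable from compound 3 to compound 4 expresses as an estimate. Compound 4 is therefore expected to give about 30000 nM, with a range of 8000 nM to 120000 nM.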

Compound 4, half-maximal effective concentration: > 26000 nM
Compound 4: no number, only a limit (the forecaster's own chance of this, stated with the estimate: 80%); the middle value is on the limit's open side.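

In this assay compound 4 gives > 26000 nM, which is only a limit and not a number, so no new step can be read, and the change from compound 3 to compound 4 has no readable size: the limit of > 26000 nM in this assay, at which 4 of the 4 values shown sit.

The compounds shown leave open how much of any of these four compounds is needed for the effect, and whether any of the structural edits changes that amount at all.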